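Carbonyl aryl swap in the chalcone-type pyrazole series

The source may hold more compounds than are shown below. What is called first, only, known or untested is meant among the compounds shown, and "the series" means these compounds.

Measured compounds:
compound 1 `COc1ccc(C(=O)/C=C/c2cn(-c3ccccc3)nc2-c2ccsc2)cc1OC` 2800 nM
compound 2 `COc1ccc(C(=O)/C=C/c2cn(-c3ccccc3)nc2-c2ccsc2)c(OC)c1` 9000 nM
compound 3 `O=C(/C=C/c1cn(-c2ccccc2)nc1-c1cccnc1)c1ccsc1` 500 nM

All three were run in a functional assay on MCF7 cells (Homo sapiens) for inhibition, read by sulforhodamine B assay, with a stated time of 72 h; a higher number here means a weaker inhibitor, a lower number a stronger inhibitor. Compound 3 gives the lowest number of the set; compound 1 is nearest to it and compound 2 furthest, both gaps beyond the scatter, so compound 3 is the strongest inhibitor of the three. Compound 3 differs from compound 1 and compound 2 in two places at once, so only the values themselves are compared here.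

Among the compounds with values here, the one step that touches the group on the carbonyl carbon is a 3.2-fold higher number from compound 1 to compound 2 (0.51 log units; beyond the scatter), a modest change in the 2,4-dimethoxyphenyl in place of 3,4-dimethoxyphenyl swap.

Compound 4 `O=C(/C=C/c1cn(-c2ccccc2)nc1-c1cccnc1)c1ccccn1` has not yet been measured. It differs from compound 3 by pyridin-2-yl in place of thiophen-3-yl on a carbonyl carbon. Within the data shown here, the only comparable step, from compound 1 to compound 2, was modest, so a step of similar size is expected in this assay, with the direction uncertain; a slight weakening is taken as the central case. Compound 4 is therefore expected to give 900 nM in this assay, within a range of 300 nM to 3000 nM. This estimate means a step of a 1.8-fold higher number from compound 3 to compound 4 (0.26 log units; within the scatter) from compound 3, and the wide range reflects how little is known about this position.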

Compound 4, half-maximal inhibitory concentration: 4200 nM
Estimate against measurement, compound 4: 4.7-fold (0.67 log units) below, and the stated range ends below it.
By their numbers in this assay, from the lowest: compound 3; then compounds 1 and 4 (each within the scatter of the next); then compound 2.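

The carbonyl position responds to more than the placing of methoxy groups on a phenyl ring: exchanging the ring itself gives an 8.4-fold higher number from compound 3 to compound 4 (0.92 log units; beyond the scatter) in this assay. This step, unlike the earlier one, was read on the core of compound 3, so the position's sensitivity now extends to a second core and to a change from a five-membered aromatic ring with sulfur to a six-membered aromatic ring with nitrogen, while the counts of hydrogen-bond donors and acceptors stay the same. No measurement at hand accounts for the loss, and the step alone cannot assign it to ring size, to the hetero atom or to where that atom sits.

Separating these would take other groups on the carbonyl carbon of the same core, such as unsubstituted phenyl, thiophen-2-yl or pyridin-4-yl, each read against thiophen-3-yl and pyridin-2-yl. Going by these compounds, the ranking of the dimethoxyphenyl groups against these rings also remains open, as compound 1 and compound 2 differ from compound 3 in two places and give no clean comparison.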